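Removing the benzamido group from the aryl ring of compound 1

The source may hold more compounds than are shown below. What is called first, only, known or untested is meant among the compounds shown, and "the series" means these compounds.

Working notes on a small cinnamic acid series. For the measured compounds named here, compound 1 `COc1ccc(/C=C\C(=O)O)c(OCc2cn(-c3ccc(NC(=O)c4ccccc4)cc3)nn2)c1CC=C(C)C` is one of two members with numbers so far. In a functional assay on A-431 cells (Homo sapiens) for cytotoxicity, read by MTT assay, with a stated time of 24 h (on this read-out higher numbers stand for weaker inhibition and lower numbers for stronger inhibition), compound 1 gives 21200 nM, the lower of the two values, though by a margin that stays within the usual scatter. The other measured member, compound 2 `COc1cccc(-n2cc(COc3c(/C=C\C(=O)O)ccc(OC)c3CC=C(C)C)nn2)c1`, carries a methoxy-substituted ring in place of the benzamido-substituted ring of compound 1; in this assay compound 2 gives 23200 nM, and on the numbers alone the two compounds are indistinguishable.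

The next member, compound 3 `COc1ccc(/C=C\C(=O)O)c(OCc2cn(-c3ccccc3)nn2)c1CC=C(C)C`, has not been measured. It differs from compound 1 in one place: hydrogen in place of benzamido on an aromatic carbon. Going by the values given here, no measured pair isolates this change. What is known is that a different substituent pattern on that same ring, as in compound 2, leaves the value where compound 1 sits, so no step beyond the scatter is expected from compound 1 to compound 3 in this assay. On that basis compound 3 is estimated at 25000 nM, with a range from 10000 nM to 60000 nM, and the expected step of a 1.2-fold higher number from compound 1 to compound 3 (0.07 log units; within the scatter) is essentially flat.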

Compound 3, half-maximal inhibitory concentration: 21200 nM
For compound 3 the middle estimate is 1.2-fold (0.07 log units) above the measured one; the measured number falls inside the stated range.
By their numbers in this assay, from the lowest: compounds 1, 3 and 2 (each within the scatter of the next).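

In this assay, the benzamido group can now be read on its own: hydrogen in its place on an aromatic carbon, para to a large group, gives no change at the digits printed from compound 1 to compound 3 (within the scatter), so the loss of this group and its six-membered aromatic ring produces no step beyond the scatter. The change from methoxy to hydrogen on an aromatic carbon gives a 1.1-fold lower number from compound 2 to compound 3 (0.04 log units; within the scatter), which makes compound 3 a single-change neighbour of both compound 1 and compound 2, and neither of the two steps leaves the scatter. Nothing available on these compounds explains why the number stays in place across these changes.

Going by these compounds, whether an amine or a longer chain on that aromatic carbon would produce a step beyond the scatter remains open, since only benzamido, methoxy and hydrogen have been compared on this aryl ring. Also open, on these data alone, is whether a change elsewhere on the shared core, for example replacing the carboxylic acid of the cinnamic acid part with an amide or an ester, would move the number in this assay when the aryl substituents do not.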